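Swapping chloro for bromo on the anilino ring

A few compounds are considered here, and "the series" means these few. Any claim that something is new, unique, unknown or untested is made for them only; others in the source may bear on it.

Measured so far:
compound 1, `CC(=O)OC[C@H]1O[C@@H](SC(=S)C2=C(Nc3ccc(Cl)cc3Cl)CC(C)(C)CC2=O)[C@H](OC(C)=O)[C@@H](OC(C)=O)[C@@H]1OC(C)=O`, 16.1 ug/mL
compound 2, `CC(=O)OC[C@H]1O[C@@H](SC(=S)C2=C(Nc3ccc(Cl)cc3)CC(C)(C)CC2=O)[C@H](OC(C)=O)[C@@H](OC(C)=O)[C@@H]1OC(C)=O`, 44.3 ug/mL

Both were tested in a functional assay on J774.2 cells (Mus musculus) for inhibition, read by Griess assay, with a stated time of 24 h; a higher number here means a weaker inhibitor, a lower number a stronger inhibitor. Within the data shown here, compound 2 has the higher of the two numbers, so of this pair it is the weaker inhibitor; the only step measured, a 2.8-fold higher number from compound 1 to compound 2 (0.44 log units; beyond the scatter), is modest but beyond the scatter.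

Compound 3, `CC(=O)OC[C@H]1O[C@@H](SC(=S)C2=C(Nc3ccc(Br)cc3)CC(C)(C)CC2=O)[C@H](OC(C)=O)[C@@H](OC(C)=O)[C@@H]1OC(C)=O`, has not yet been measured. It differs from compound 2 in one place: bromo in place of chloro on an aromatic carbon. Among the measured compounds shown here, no measured step involves bromo, so the one step available, from compound 1 to compound 2, bears on it only indirectly: it shows that removing the chloro altogether costs a modest amount, which hints that a halogen at this spot matters somewhat. Exchanging one halogen for another is expected to change little. Compound 3 is therefore expected to give about 40 ug/mL, within the range 20 ug/mL to 80 ug/mL, a step of a 1.1-fold lower number from compound 2 to compound 3 (0.04 log units; within the scatter) that is expected to stay within the scatter.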

Compound 3, half-maximal inhibitory concentration: 7.7 ug/mL
For compound 3 the middle estimate is 5.2-fold (0.72 log units) above the measured one, outside the stated range (below it).
By their numbers in this assay, from the lowest: compound 3; then compound 1; then compound 2.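

In this assay, exchanging one halogen for another on this aromatic carbon, para to a large group, is not a silent change: there is a 5.8-fold lower number from compound 2 to compound 3 (0.76 log units; beyond the scatter), so the identity of the halogen matters here, something compound 1 and compound 2 could not show. The 4-bromophenyl group also compares well with the 2,4-dichlorophenyl group, with a 2.1-fold lower number from compound 1 to compound 3 (0.32 log units; beyond the scatter), so among these three compounds the lowest number comes with a single halogen on the ring, not two. Nothing available explains why bromo and chloro differ at this position.

Still open, on these data alone, is whether the gain continues with iodo or reverses with fluoro at the same place. As far as these compounds go, it is also open whether a non-halogen group such as methyl or methoxy could match bromo there.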